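The compounds below may be only part of what the source reports. "The series", "measured", "known", "first", "only" and "open" are said of these compounds alone.

Compound 2 `COc1cc(-c2cc(-c3cc(C(C)C)c(O)cc3C)[nH]c(=O)c2C#N)ccc1O` gives 42% in a functional assay for inhibition, tested at 80 ug/mL (a lower number here means a weaker effect, a higher number a stronger effect of the compound at the concentration tested), the lowest of the two numbers at hand, while compound 1 `COc1ccc(-c2cc(-c3cc(C(C)C)c(O)cc3C)[nH]c(=O)c2C#N)c(OC)c1` gives 55%. For the measured compounds named here, the single measured step, a number 13 percentage points lower from compound 1 to compound 2 (beyond the scatter), swapped the group on the same aromatic carbon. Compound 3 `Cc1cc(O)c(C(C)C)cc1-c1cc(-c2ccccc2Cl)c(C#N)c(=O)[nH]1` differs from compound 2 there as well: 2-chlorophenyl in place of 4-hydroxy-3-methoxyphenyl on an aromatic carbon. Going by the values given here, that earlier step is the only guide, and it did not involve a 2-chlorophenyl group, so the direction is uncertain and a step of roughly that size in either direction seems possible. The expected step is a number 3 percentage points higher from compound 2 to compound 3 (within the scatter). Compound 3 is therefore estimated at 45%, with a likely range from 25% to 65%.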

Compound 3, a percentage reported as inhibition, at one concentration (the size of the read-out at that concentration, not a potency): 32%
Estimate against measurement, compound 3: 13 percentage points above, and the stated range covers the measured number.
By their numbers in this assay, from the lowest: compounds 3 and 2 (each within the scatter of the next); then compound 1.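

In this assay, a ring with no hydrogen-bond donors or acceptors can sit at this position: 2-chlorophenyl in place of 4-hydroxy-3-methoxyphenyl gives a number 10 percentage points lower from compound 2 to compound 3 (within the scatter), so the two groups cannot be told apart here. The same group in place of 2,4-dimethoxyphenyl gives a number 23 percentage points lower from compound 1 to compound 3 (beyond the scatter), a real loss. No evidence at hand explains either step. Still open, from the compounds shown here alone, is how a plain phenyl, or a phenyl carrying an amine or a carboxylic acid, would read at this position. Also open, going by these compounds, is whether the chlorine itself matters.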